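The source may report more compounds than this note shows. Statements on the series, on what has been measured and on what is new or still open speak of the compounds shown alone.

Measured so far in an ADME assay on NIH3T3 cells (Mus musculus) for cytotoxicity, read by MTT assay, with a stated time of 24 h; a lower number here means a stronger inhibitor, a higher number a weaker inhibitor: compound 1 `Cn1nnnc1SCC(=O)N/N=c1/scc(-c2ccccc2)n1-c1ccccc1` gives 173 ug/mL; compound 2 `O=C(CSc1nnnn1-c1ccccc1)N/N=c1/scc(-c2ccccc2)n1-c1ccccc1` gives 417 ug/mL. Compound 3 `N#Cc1ccc(-c2cs/c(=N/NC(=O)CSc3ncccn3)n2-c2ccccc2)cc1` gives only a limit of this assay, < 3.9 ug/mL.

Compound 3 thus stands at the limit of < 3.9 ug/mL in this assay, at which 1 of the 3 values shown sits, and no number is known for it. Compound 4 `O=C(CSc1ncccn1)N/N=c1/scc(-c2ccccc2)n1-c1ccccc1` differs from it in one place: hydrogen in place of cyano on an aromatic carbon. Within the data shown here, no measured step covers this change. Among the measured compounds shown here, the single measured step, a 2.4-fold higher number from compound 1 to compound 2 (0.38 log units; beyond the scatter), concerns another part of the shared core and is modest. Compound 1 and compound 2, both carrying phenyl where compound 4 does, sit far from the limit of compound 3, so a large upward step is expected, an at least 25-fold higher number from compound 3 to compound 4 (1.40 log units; beyond the scatter). Compound 4 is estimated at 100 ug/mL, within a range from 10 ug/mL to 400 ug/mL.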

Compound 4, half-maximal inhibitory concentration: 107 ug/mL
Beside the measured number, compound 4's estimate is 1.1-fold (0.03 log units) below it; measured number inside the range.
By their numbers in this assay, from the lowest: compounds 4 and 1 (each within the scatter of the next); then compound 2. At a limit, below all of these: compound 3.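

In this assay, among these compounds, the change from 4-cyanophenyl to phenyl gives the first measured step at this position, and it is large: an at least 27-fold higher number from compound 3 to compound 4 (1.43 log units; beyond the scatter). Compound 3 carries only a limit of the assay: the limit of < 3.9 ug/mL in this assay, at which 1 of the 4 values shown sits. On the sulfur, pyrimidin-2-yl in place of 1-phenyl-1H-tetrazol-5-yl gives a 3.9-fold lower number from compound 2 to compound 4 (0.59 log units; beyond the scatter), while pyrimidin-2-yl in place of 1-methyl-1H-tetrazol-5-yl gives a 1.6-fold lower number from compound 1 to compound 4 (0.21 log units; within the scatter).

On these data alone, the full size of the cyano step stays open, since compound 3 has no exact number. The compounds shown also leave open how an amine or a carboxylic acid would read at the same place on the phenyl ring, and whether the step would hold with either tetrazolyl group on the sulfur.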